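The source may report more compounds than this note shows. Statements on the series, on what has been measured and on what is new or still open speak of the compounds shown alone.

Compound 1 `O=C(Nc1cccc(-n2cc(-c3ccncc3)c(-c3ccc(Cl)c(O)c3)n2)c1)Nc1cccc(C(F)(F)F)c1` gives 4690 nM in a functional assay on 786-0 cells (Homo sapiens) for inhibition, read by sulforhodamine B assay, with a stated time of 48 h; on this read-out lower numbers stand for stronger inhibition of growth and higher numbers for weaker inhibition of growth.
Compound 2 `COc1cc(-c2nn(-c3cccc(NC(=O)Nc4cc(C(F)(F)F)cc(C(F)(F)F)c4)c3)cc2-c2ccncc2)ccc1Cl` gives 950 nM in this assay.

Of the two numbers shown, compound 2 stands at the lower one, and its only neighbour, compound 1, returns a number a good deal higher, a gap beyond the usual scatter of this kind of measurement. Compound 3 `O=C(Nc1cccc(-n2cc(-c3ccncc3)c(-c3ccc(Cl)c(O)c3)n2)c1)Nc1cc(C(F)(F)F)cc(C(F)(F)F)c1` has not yet been measured. It differs from compound 2 in one place: hydrogen in place of methyl on an oxygen on an aromatic ring. Going by the values given here, compound 1 also carries a 4-chloro-3-hydroxyphenyl group, but it differs from compound 2 in a second place as well, so no single step between measured compounds isolates this change; the two values of compound 1 and compound 2 show only that the pair as a whole lies apart. For compound 3 the estimated step in this assay is a 1.6-fold higher number from compound 2 to compound 3 (0.20 log units; within the scatter), small and of uncertain direction, since nothing measured pins the effect of this change alone. Compound 3 is accordingly expected to give about 1500 nM in this assay, within a range from 500 nM to 5000 nM.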

Compound 3, concentration for 50% growth inhibition: 1170 nM
Estimate against measurement, compound 3: 1.3-fold (0.11 log units) above, and the stated range covers the measured number.
By their numbers in this assay, from the lowest: compounds 2 and 3 (each within the scatter of the next); then compound 1.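

In this assay, replacing methoxy with hydroxy in going from 4-chloro-3-methoxyphenyl to 4-chloro-3-hydroxyphenyl gives a 1.2-fold higher number from compound 2 to compound 3 (0.09 log units; within the scatter), so this single step shows that the methyl on this oxygen can give way to hydrogen without a change that stands clear of the scatter, something the two earlier compounds, which differ in two places, could not show. The new compound also isolates the second difference: trifluoromethyl in place of hydrogen on an aromatic carbon gives a 4.0-fold lower number from compound 1 to compound 3 (0.60 log units; beyond the scatter), a modest step but one beyond the scatter, and the only one of the two here that is. Nothing available explains either step.

On these data alone, whether the methoxy to hydroxy step stays this small with an ethoxy group or an amine at this place on the ring remains open. As far as these compounds go, the trifluoromethyl step is read only carrying the hydroxy group, so it also remains open whether the step would be of similar size with methoxy in that place.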